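The compounds below may be only part of what the source reports. "The series", "measured", "known", "first", "only" and "open" are said of these compounds alone.

Measured so far in an ADME assay on HepG2 2.2.15 cells (Homo sapiens) for cytotoxicity, read by MTT assay, with a stated time of 8 days; on this read-out higher numbers stand for lower toxicity in this test and lower numbers for higher toxicity in this test:
- compound 1 `N#Cc1ccc(Cn2nc(-c3cc(Cl)c(NCCO)nc3F)c3ccccc3c2=O)cc1` gives 32100 nM
- compound 2 `COCCNc1nc(F)c(-c2nn(Cc3ccc(C#N)cc3)c(=O)c3ccccc23)cc1Cl` gives > 100000 nM, a limit of the assay
- compound 3 `COC(=O)CCNc1nc(F)c(-c2nn(Cc3ccc(C#N)cc3)c(=O)c3ccccc23)cc1Cl` gives > 100000 nM, a limit of the assay

Compound 3 stands at the limit of > 100000 nM in this assay, at which 2 of the 3 values shown sit, so its position is a limit and not a number.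

The next compound is compound 4 `N#Cc1ccc(Cn2nc(-c3cc(Cl)c(NCC(O)CO)nc3F)c3ccccc3c2=O)cc1`. The change is 1,2-dihydroxyethyl in place of (methoxycarbonyl)methyl on a saturated chain carbon bound to a nitrogen on an aromatic ring, in words 1,2-dihydroxyethyl in place of (methoxycarbonyl)methyl on a saturated chain carbon bound to a nitrogen on an aromatic ring.

Among the measured compounds shown here, two measured steps bear on it, both leading away from the free hydroxy of compound 1: an at least 3.1-fold higher number from compound 1 to compound 2 (0.49 log units; beyond the scatter) and an at least 3.1-fold higher number from compound 1 to compound 3 (0.49 log units; beyond the scatter). Both are beyond the scatter. A third step, a step that the two limits leave unreadable from compound 2 to compound 3, gives no size.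

Compound 4 again carries free hydroxy groups, as does compound 1 at 32100 nM, so a modest move to a lower number in this assay is expected. The expected step is an at least 2.0-fold lower number from compound 3 to compound 4 (0.30 log units; that floor lies within the scatter). For compound 4 the estimate is 50000 nM, with an expected range from 20000 nM to 100000 nM.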

Compound 4, half-maximal cytotoxic concentration: > 100000 nM
Compound 4: a limit, no number; the forecaster's own chance of this, stated with the estimate: 35%; middle value at least 2.0-fold (0.30 log units) from the limit.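

In this assay compound 4 gives > 100000 nM, a limit of the assay and not a number. The added hydroxymethyl gives an at least 3.1-fold higher number from compound 1 to compound 4 (0.49 log units; beyond the scatter), so free hydroxy on the chain does not by itself hold the number where compound 1 stands, and of the four compounds only compound 1 gives a value short of the limit. The steps from compound 2 and from compound 3 to compound 4 cannot be read because all three compounds sit at the same limit: the limit of > 100000 nM in this assay, at which 3 of the 4 values shown sit.

Going by these compounds, how far compound 2, compound 3 and compound 4 lie beyond the limit stays open, and with it any order among them in this assay. Also open, on these data alone, is whether an amine, a carboxylic acid or a longer chain in this place would stay at the limit or give a lower number.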